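Benzyl substituent swap in the series: cytotoxicity notes

The source may report more compounds than this note shows. Statements on the series, on what has been measured and on what is new or still open speak of the compounds shown alone.

Values in a toxicity assay on MDCK cells (Canis lupus familiaris) for cytotoxicity, read by crystal violet staining, with a stated time of 48 h; on this read-out lower numbers stand for higher toxicity in this test and higher numbers for lower toxicity in this test:
compound 1 `Cc1ccc2[nH]c(=O)c(CN(Cc3ccc(O)cc3)Cc3ccc(C(C)(C)C)cc3)cc2c1`: 4900 nM
compound 2 `COc1ccc(CN(Cc2ccc(C(C)(C)C)cc2)Cc2cc3cc(C)ccc3[nH]c2=O)cc1`: a limit, > 10000 nM
compound 3 `Cc1ccc2[nH]c(=O)c(CN(Cc3ccc(OC(F)(F)F)cc3)Cc3ccc(C(C)(C)C)cc3)cc2c1`: a limit, > 5000 nM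

Compound 3 stands only as a limit of this assay (the limit of > 5000 nM in this assay, at which 1 of the 3 values shown sits), and compound 2 likewise stands only as a limit (the limit of > 10000 nM in this assay, at which 1 of the 3 values shown sits). Within the data shown here, compound 1 is the one member with a numeric value.

Compound 4 `Cc1ccc2[nH]c(=O)c(CN(Cc3ccc(SC(F)F)cc3)Cc3ccc(C(C)(C)C)cc3)cc2c1` differs from compound 3 by (difluoromethyl)sulfanyl in place of trifluoromethoxy on an aromatic carbon.

The steps bearing on this change all alter the same group on the same benzyl arm: an at least 1.0-fold higher number from compound 1 to compound 3 (0.00 log units; that floor lies within the scatter), an at least 2.0-fold higher number from compound 1 to compound 2 (0.30 log units; that floor lies within the scatter), and a step that the two limits leave unreadable from compound 2 to compound 3. None of them reveals a readable step beyond the scatter, so no step beyond the scatter is expected in this assay from compound 3 to compound 4.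

Compound 4 is therefore estimated at 6000 nM, within 2500 nM to 15000 nM, and the expected step is a step that the limit leaves unreadable from compound 3 to compound 4.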

Compound 4, half-maximal cytotoxic concentration: > 5000 nM
Compound 4: only a limit was reported (the forecaster's own chance of this, stated with the estimate: 50%); the middle value lies beyond the limit too.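

Compound 4 stands only as a limit in this assay, the same limit as compound 3: the limit of > 5000 nM in this assay, at which 2 of the 4 values shown sit. The steps to compound 4 from compound 2 and from compound 3 cannot be read, so the exchange of trifluoromethoxy for (difluoromethyl)sulfanyl has no size here. Among these compounds, the one step that can be read is an at least 1.0-fold higher number from compound 1 to compound 4 (0.00 log units; that floor lies within the scatter), so a group carrying sulfur at this place on the benzyl arm adds a further member with no step beyond the scatter against the hydroxy compound.

Among the compounds shown here, how far compound 2, compound 3 and compound 4 lie from one another stays open, with compound 1 the only member holding a numeric value. Also open, on these data alone, is whether an amine or a carboxylic acid at this place would give a numeric value in this assay.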